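Swapping Methoxy for Fluoro at the Assay Limit

This account rests on a few compounds, and the source may have more. Where it says the series, first, only, none or still open, it means among the compounds named here.

Of the compounds shown here, two with a shared core have been measured so far. In an ADME assay on THP-1 cells (Homo sapiens) for cytotoxicity, read by flow cytometry and propidium iodide staining, with a stated time of 72 h (a higher number here means a weaker inhibitor, a lower number a stronger inhibitor), compound 1 `Nc1ccc2oc(-c3cccc(F)c3)cc(=O)c2c1` gives > 125000 nM, which is a limit and not a number. Compound 2 `COc1ccccc1-c1oc2ccc(NC(C)=O)cc2c(=O)c1O` gives > 125000 nM in this assay, which is also a limit, so its true value is not known. Compound 3 `CC(=O)Nc1ccc2oc(-c3ccccc3F)c(O)c(=O)c2c1` differs from compound 2 in one place, with fluoro in place of methoxy on an aromatic carbon, ortho to a large group (fluoro in place of methoxy on an aromatic carbon). This turns 2-methoxyphenyl into 2-fluorophenyl. Going by the values given here, no measured pair shows what a single change does here, so the forecast rests on (the limit of > 125000 nM in this assay, at which 2 of the 2 values shown sit). A change beyond the scatter is not expected. The estimated step of a number no higher from compound 2 to compound 3 (the limit leaves the size open) is therefore small. For compound 3 the expected value is 125000 nM, with an estimated range from 60000 nM to 250000 nM.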

Compound 3, half-maximal inhibitory concentration: 47000 nM
For compound 3 the middle estimate is 2.7-fold (0.42 log units) above the measured one; the measured number lies below the stated range.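

Fluoro in place of methoxy on this aromatic carbon, ortho to a large group, gives an at least 2.6-fold lower number from compound 2 to compound 3 (0.42 log units; beyond the scatter). Compound 3, at 47000 nM in this assay, is the first compound shown with a true number, and it shows that a single small swap at this position can bring a compound within the measurable range of this assay. On these data alone, compound 2 gives > 125000 nM, which is a limit, and the real size of the step therefore remains unknown and may be larger than the one printed.

This one pair cannot tell whether the shift comes from gaining fluoro or from losing methoxy. Plain hydrogen, chloro or methyl at the same position would help separate the two, and the same swap on a different core would test whether the effect carries over.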